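A few compounds are considered here, and "the series" means these few. Any claim that something is new, unique, unknown or untested is made for them only; others in the source may bear on it.

Measured so far in a functional assay on H184B5F5/M10 cells (Homo sapiens) for antiproliferative activity, read by XTT assay, with a stated time of 72 h; on this read-out higher numbers stand for weaker inhibition and lower numbers for stronger inhibition:
compound 1, `COc1ccc(C(=O)/C=C/c2nc3ccccc3cc2-c2ccc(OC)cc2)cc1`, gives > 10000 nM, a limit of the assay.
compound 2, `COc1ccc(-c2cc3ccccc3nc2/C=C/C(=O)c2ccc([N+](=O)[O-])cc2)cc1`, gives 6100 nM.
compound 3, `COc1ccc(-c2cc3ccccc3nc2/C=C/C(=O)c2ccc[nH]2)cc1`, gives > 10000 nM, again a limit of the assay.

Compound 1 stands at the limit, as does compound 3 (the limit of > 10000 nM in this assay, at which 2 of the 3 values shown sit); only compound 2 carries a number, and the step of an at least 1.6-fold lower number from compound 1 to compound 2 (0.21 log units; that floor lies within the scatter) reaches just a floor within the scatter. Compound 4, `COc1ccc(-c2cc3ccccc3nc2/C=C/C(=O)c2sccc2N)cc1`, differs from compound 1 on the carbonyl carbon: 3-aminothiophen-2-yl in place of 4-methoxyphenyl on a carbonyl carbon. The nearest measured step, 1H-pyrrol-2-yl in place of 4-methoxyphenyl on a carbonyl carbon, is a step that the two limits leave unreadable from compound 1 to compound 3, and an at least 1.6-fold higher number from compound 2 to compound 3 (0.21 log units; that floor lies within the scatter) gives only a floor. Going by the values given here, no measured step points to a gain in this assay from such a swap, so compound 4 is expected to stay near the limit, the estimated step being a step that the limit leaves unreadable from compound 1 to compound 4, within the scatter. The estimate for compound 4 is 12000 nM, between 4000 nM and 40000 nM.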

Compound 4, half-maximal inhibitory concentration: > 10000 nM
Compound 4: only a limit was reported; the forecaster's own chance of this, stated with the estimate: 65%; the middle value is on the limit's open side.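

In this assay, compound 4 gives only a limit, > 10000 nM. Going by these compounds alone, its steps from compound 1 and compound 3 cannot be read, and the one readable step, an at least 1.6-fold higher number from compound 2 to compound 4 (0.21 log units; that floor lies within the scatter), reaches only a floor within the scatter. A second five-membered aromatic ring on the carbonyl carbon, now one carrying an amine, therefore yields no number, and compound 2 remains the only compound with one: the limit of > 10000 nM in this assay, at which 3 of the 4 values shown sit.

Still open, going by these compounds, is how a 4-aminophenyl or a 4-carboxyphenyl group on this carbonyl carbon would read. Also open, on these data alone, is whether a change elsewhere on the shared core would give values clear of the limit.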